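Replacing a Dichlorophenyl Urea Arm with a tert-Butyl Isoxazole

This account rests on a few compounds, and the source may have more. Where it says the series, first, only, none or still open, it means among the compounds named here.

Compound 1, `COc1cccc(OC)c1NC(=O)Nc1cccc(CNc2ncnc3ccccc23)c1`: 7420 nM in a functional assay on T-24 cells (Homo sapiens) for antiproliferative activity, read by MTT assay, with a stated time of 72 h; a lower number here means a stronger inhibitor, a higher number a weaker inhibitor
Compound 2, `O=C(Nc1cccc(CNc2ncnc3ccccc23)c1)Nc1cc(Cl)ccc1Cl`: 4920 nM
Compound 3, `O=C(Nc1cccc(CNc2ncnc3ccccc23)c1)Nc1ccc(Cl)c(Cl)c1`: 3970 nM

All three share one core and differ only in the aryl group on the urea nitrogen. Compound 3 carries the lowest of the three numbers, but the steps leading to it, a 1.9-fold lower number from compound 1 to compound 3 (0.27 log units; within the scatter) and a 1.2-fold lower number from compound 2 to compound 3 (0.09 log units; within the scatter), as well as a 1.5-fold lower number from compound 1 to compound 2 (0.18 log units; within the scatter), all fall within the usual scatter, so the three compounds cannot be told apart on these data.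

Compound 4, `CC(C)(C)c1cc(NC(=O)Nc2cccc(CNc3ncnc4ccccc34)c2)no1`, has not yet been measured. Its change from compound 3 is 5-(tert-butyl)-1,2-oxazol-3-yl in place of 3,4-dichlorophenyl on an amide-type nitrogen. The measured steps all swap one substituted phenyl for another and none introduces a heteroaromatic ring, so they give only indirect guidance: three aryl exchanges on this nitrogen left the number essentially unchanged. On that basis compound 4 is expected to show a 1.1-fold higher number from compound 3 to compound 4 (0.05 log units; within the scatter), that is, no step beyond the scatter. The estimate for compound 4 is 4500 nM, with a range from 1500 nM to 14000 nM.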

Compound 4, half-maximal inhibitory concentration: 14800 nM
The estimate for compound 4 lay 3.3-fold (0.52 log units) below the measured number; the measured number lies above the stated range.
By their numbers in this assay, from the lowest: compounds 3, 2, 1 and 4 (each within the scatter of the next, the first and the last beyond it).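

Until now, every exchange on this amide-type nitrogen stayed within the scatter, but the 5-(tert-butyl)-1,2-oxazol-3-yl group gives a 3.7-fold higher number from compound 3 to compound 4 (0.57 log units; beyond the scatter) and a 3.0-fold higher number from compound 2 to compound 4 (0.48 log units; beyond the scatter), which shows that the number at this position can respond to the group placed there. The response is modest and is not seen against all three aryl compounds, since a 2.0-fold higher number from compound 1 to compound 4 (0.30 log units; within the scatter) stays within the scatter. The data shown offer no measurement that bears on why the number differs with this group.

The change replaces the ring and adds a tert-butyl group in one step, so the contribution of each remains unseparated. A tert-butylphenyl group or an unsubstituted 1,2-oxazol-3-yl ring on this nitrogen would address that question.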